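The source may report more compounds than this note shows. Statements on the series, on what has been measured and on what is new or still open speak of the compounds shown alone.

For the measured compounds named here, compound 2 `C#CCSc1nc(Nc2ccccc2)c2ccncc2n1` gives 29400 nM in a functional assay on HepG2 cells (Homo sapiens) for inhibition, read by MTT assay, with a stated time of 72 h (a lower number here means a stronger inhibitor, a higher number a weaker inhibitor), the only number among the two values shown. Compound 1 `C#CCSc1nc(NCCC(C)C)c2ccncc2n1` returns in this assay > 80000 nM, which is a limit of the assay and not a number, as recorded in the limit of > 80000 nM in this assay, at which 1 of the 2 values shown sits. Going by the values given here, the one measured step, an at least 2.7-fold lower number from compound 1 to compound 2 (0.43 log units; beyond the scatter), is the sole comparison available, and it concerns a different exchange.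

Compound 3 `C#CCSc1nc(N2CCN(C)CC2)c2ccncc2n1` differs from compound 2 by 4-methylpiperazin-1-yl in place of anilino on an aromatic carbon. Among the compounds with values here, no measured step bears directly on this change. Within the data shown here, the only step, an at least 2.7-fold lower number from compound 1 to compound 2 (0.43 log units; beyond the scatter), indicates that the anilino group supports inhibition better than an alkyl chain on that nitrogen, and compound 3 gives up that anilino group. A step toward a higher number is therefore expected, of modest size, though it may not exceed the scatter. The estimate for compound 3 is 50000 nM, with a range from 15000 nM to 120000 nM. The expected step is a 1.7-fold higher number from compound 2 to compound 3 (0.23 log units; within the scatter).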

Compound 3, half-maximal inhibitory concentration: > 80000 nM
Compound 3 gave a limit, no number (the forecaster's own chance of this, stated with the estimate: 35%); middle value at least 1.6-fold (0.20 log units) from the limit.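

Exchanging anilino for 4-methylpiperazin-1-yl on this aromatic carbon gives an at least 2.7-fold higher number from compound 2 to compound 3 (0.43 log units; beyond the scatter), so a six-membered ring with the same count of heavy atoms does not by itself keep what inhibition compound 2 shows. Compound 3 gives a limit and not a number in this assay: the limit of > 80000 nM in this assay, at which 2 of the 3 values shown sit. The step between compound 1 and compound 3 cannot be read, so the isopentylamino and 4-methylpiperazin-1-yl groups cannot be ranked against each other.

The compounds shown leave open whether the number for compound 2 depends on the aromatic ring of anilino or on its hydrogen-bond donor, a question that a cyclohexylamino or an N-methylanilino group on this carbon would address. They also leave open how a chloro or methoxy group on the anilino ring would act.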